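Swapping the Benzyl Group in a Cytotoxicity Series

The source may report more compounds than this note shows. Statements on the series, on what has been measured and on what is new or still open speak of the compounds shown alone.

Measured compounds:
compound 1, `Nc1ccc(/C=C2\SC(=O)N(Cc3cccc(Cl)c3)C2=O)cc1`: 10000 nM
compound 2, `C=C(Br)C(=O)Nc1cccc(/C=C2\SC(=O)N(Cc3cccc(Cl)c3)C2=O)c1`: 1700 nM
compound 3, `Nc1ccc(/C=C2\SC(=O)N(Cc3ccc(F)cc3)C2=O)cc1`: 36000 nM

These three were tested in a functional assay on FM3A cells (Mus musculus) for cytotoxicity, read by cell counting, with a stated time of 2 days; a lower number here means a stronger inhibitor, a higher number a weaker inhibitor. Compound 2 gives the lowest number of the three, and its steps to compound 1 and to compound 3 both lie beyond the scatter. Compound 1 and compound 3 differ in one place, (4-fluorophenyl in place of 3-chlorophenyl on a saturated chain carbon bound to an amide-type nitrogen in a ring), and that change made a step of a 3.6-fold higher number from compound 1 to compound 3 (0.56 log units; beyond the scatter). How the core of compound 2 differs from the core of compound 1 is not broken down here. The unmeasured compound 4, `C=C(Br)C(=O)Nc1cccc(/C=C2\SC(=O)N(Cc3ccc(F)cc3)C2=O)c1`, arises from compound 2 by the same change, (4-fluorophenyl in place of 3-chlorophenyl on a saturated chain carbon bound to an amide-type nitrogen in a ring). Resting on the one earlier instance, a 3.6-fold higher number from compound 1 to compound 3 (0.56 log units; beyond the scatter), the expected step is a 3.5-fold higher number from compound 2 to compound 4 (0.55 log units; beyond the scatter). Compound 4 is therefore estimated to give 6000 nM in this assay, with a likely range from 2500 nM to 15000 nM.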

Compound 4, half-maximal inhibitory concentration: 920 nM
For compound 4 the middle estimate is 6.5-fold (0.81 log units) above the measured one; the measured number lies below the stated range.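

In this assay, exchanging 3-chlorobenzyl for 4-fluorobenzyl gave a 1.8-fold lower number from compound 2 to compound 4 (0.27 log units; within the scatter), so compound 2 and compound 4 cannot be told apart on this measurement. Among the compounds shown here, the change did not carry over from one core to the other with the same size, and the two instances disagree: the same change on two cores in this assay, a 3.6-fold higher number (0.56 log units; beyond the scatter) from compound 1 to compound 3 and a 1.8-fold lower number (0.27 log units; within the scatter) from compound 2 to compound 4, 6.7-fold (0.82 log units) apart, beyond the scatter of two such steps With only two pairs, this shows that the step differs between these two cores, but it does not show which feature of the cores is responsible or what the change would do on a third core.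

Still open, as far as these compounds go, is whether a plain acetamide in place of the bromoacrylamide would follow either pattern. An unsubstituted benzyl group in place of either substituted benzyl group also remains to be placed.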